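Ethyl to methyl on the ring amine of compound 1

The source may hold more compounds than are shown below. What is called first, only, known or untested is meant among the compounds shown, and "the series" means these compounds.

Measured so far:
compound 1, `CCN1CCN(c2c(C(C)=O)c(=O)oc3cc(Nc4ncc(F)c(-c5ccc(F)cc5OC)n4)ccc23)CC1` — 550 nM
compound 2, `COc1ccccc1-c1ccnc(Nc2ccc3c(N4CCNCC4)cc(=O)oc3c2)n1` — 1340 nM

Both numbers come from a functional assay on MV4-11 cells (Homo sapiens) for inhibition, read by luminescence and CellTiter-Glo, with a stated time of 72 h; a higher number here means a weaker inhibitor, a lower number a stronger inhibitor. Among the compounds with values here, compound 1 has the lowest of the two numbers; compound 2, its only neighbour, sits at a higher number, and that gap is beyond the usual scatter. Within the data shown here, compound 2 differs from compound 1 in several places at once, so the two values show only that compound 1 is the stronger of the pair, not which of the differences carries the effect.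

Compound 3, `COc1cc(F)ccc1-c1nc(Nc2ccc3c(N4CCN(C)CC4)c(C(C)=O)c(=O)oc3c2)ncc1F`, has not yet been measured. Relative to compound 1 the change is hydrogen in place of methyl on a saturated chain carbon bound to an amine nitrogen in a ring, that is, 4-ethylpiperazin-1-yl becomes 4-methylpiperazin-1-yl. Among the measured compounds shown here, no pair of measured compounds isolates this change, so there is no measured step to lean on. A change of a single carbon on a saturated chain bound to a ring amine nitrogen is expected to move the number little: the step of a 1.1-fold lower number from compound 1 to compound 3 (0.04 log units; within the scatter) is expected to stay within the scatter, in either direction. On that basis compound 3 is estimated at 500 nM, with a range from 250 nM to 1100 nM.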

Compound 3, half-maximal inhibitory concentration: 400 nM
Estimate against measurement, compound 3: 1.3-fold (0.10 log units) above; the range from low to high includes it.
By their numbers in this assay, from the lowest: compounds 3 and 1 (each within the scatter of the next); then compound 2.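

In this assay, within the data shown here, the step of a 1.4-fold lower number from compound 1 to compound 3 (0.14 log units; within the scatter) is the first reading that isolates this position, which the earlier pair could not do because compound 2 differs from compound 1 in several places at once. With everything else in the structure held constant, 4-ethylpiperazin-1-yl and 4-methylpiperazin-1-yl cannot be told apart in this assay, so the one carbon that leaves the saturated chain on the ring amine nitrogen has no readable effect on the number. No measured property of these compounds bears on this result, so it stands as an observation without an explanation.

These two alkyl groups span only a narrow range, so the compounds shown leave open how a longer chain such as n-propyl, a branched group such as isopropyl, or a chain ending in a hydroxyl group would read on that ring amine nitrogen. They also leave open the effect of the free amine hydrogen at that nitrogen, since compound 2 carries it but differs from compound 3 in several other places as well.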